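This account rests on a few compounds, and the source may have more. Where it says the series, first, only, none or still open, it means among the compounds named here.

Of the compounds shown here, two have been tested so far in a functional assay on MIA PaCa-2 cells (Homo sapiens) for cytotoxicity, read by WST assay, with a stated time of 24 h; a lower number here means a stronger inhibitor, a higher number a weaker inhibitor. Compound 1 (`COc1ccc2[nH]cc(C(=O)/C(C#N)=C/c3c[nH]c4cc(F)ccc34)c2c1`) gives > 50000 nM, which is a limit and not a number. Compound 2 (`N#C/C(=C\c1cn(Cc2ccc(Cl)cc2)c2ccccc12)C(=O)c1c[nH]c2cc(F)ccc12`) gives > 50000 nM, which is also a limit. The position of compound 2 therefore comes down to one shared reading: the limit of > 50000 nM in this assay, at which 2 of the 2 values shown sit.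

Compound 3 (`COc1ccc2c(C(=O)/C(C#N)=C/c3cn(Cc4ccc(Cl)cc4)c4ccccc34)c[nH]c2c1`) differs from compound 2 in one group: methoxy in place of fluoro on an aromatic carbon. Methoxy takes the place of fluoro on an aromatic carbon, so 6-fluoro-1H-indol-3-yl becomes 6-methoxy-1H-indol-3-yl. Going by the values given here, no measured pair shows what a single change of this kind does in this assay, so the forecast starts from compound 2 and its limit of > 50000 nM. The estimated step of a number no higher from compound 2 to compound 3 (the limit leaves the size open) is expected to stay within the usual scatter. For compound 3 the expected value is 50000 nM, with an estimated range from 25000 nM to 100000 nM.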

Compound 3, half-maximal inhibitory concentration: > 50000 nM
Compound 3: a limit, no number; the forecaster's own chance of this, stated with the estimate: 75%; the middle value lies on the limit itself.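

Going by these compounds alone, no step from compound 2 to compound 3 can be read, because both values are limits and not numbers: the limit of > 50000 nM in this assay, at which 3 of the 3 values shown sit. What methoxy in place of fluoro on an aromatic carbon does to the activity of these compounds remains open, since neither compound gives a number to compare.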